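Chloro for Fluoro: What Compound 4 Might Show

The source may report more compounds than this note shows. Statements on the series, on what has been measured and on what is new or still open speak of the compounds shown alone.

Compound 1, `CC[C@H](CCn1cncn1)c1ccc(F)cc1`: 110 ug/mL
Compound 2, `CC[C@H](CCn1cncn1)c1ccc(Cl)cc1`: 57 ug/mL
Compound 3, `CCC[C@@H](CCn1cncn1)c1ccc(F)cc1`: 56.9 ug/mL

Of the compounds shown here, three have been measured in an ADME assay on RD cells (Homo sapiens) for cytotoxicity, read by MTT assay, with a stated time of 3 days; on this read-out lower numbers stand for higher toxicity in this test and higher numbers for lower toxicity in this test. Compound 1 and compound 2 share a core and differ in one place: chloro in place of fluoro on an aromatic carbon. This change gave a 1.9-fold lower number from compound 1 to compound 2 (0.29 log units; within the scatter). Compound 3 carries a core that differs from that of compound 1; how the two cores differ is not broken down here. Against its two neighbours, compound 3 gives 56.9 ug/mL, which lies within the scatter of both compound 1 and compound 2.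

Compound 4, `CCC[C@@H](CCn1cncn1)c1ccc(Cl)cc1`, has not yet been measured in this assay. It is related to compound 3 by the same change: chloro in place of fluoro on an aromatic carbon. Going by the values given here, the one earlier example of this change, the step from compound 1 to compound 2, stayed within the scatter. On that basis a small step of a 1.6-fold lower number from compound 3 to compound 4 (0.21 log units; within the scatter) is expected in this assay, because of a 1.9-fold lower number from compound 1 to compound 2 (0.29 log units; within the scatter). Compound 4 is estimated at 35 ug/mL, with a likely range from 18 ug/mL to 80 ug/mL.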

Compound 4, half-maximal cytotoxic concentration: 40.8 ug/mL
Estimate against measurement, compound 4: 1.2-fold (0.07 log units) below; the range from low to high includes it.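

In this assay the swap of chloro for fluoro on an aromatic carbon gave a 1.4-fold lower number from compound 3 to compound 4 (0.14 log units; within the scatter) on the core of compound 3, and this step can be set beside the earlier one on the core of compound 1: the same change on two cores in this assay, a 1.9-fold lower number (0.29 log units; within the scatter) from compound 1 to compound 2 and a 1.4-fold lower number (0.14 log units; within the scatter) from compound 3 to compound 4, 1.4-fold (0.14 log units) apart, within the scatter of two such steps. Across these two cores the change therefore read alike, with both steps small and neither beyond the scatter. This does not establish a real effect of the change on this read-out: each step on its own lies within the scatter, and two cores give no firm guide to a third.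

The compounds shown leave open how a bromo, methyl or trifluoromethyl group on that same aromatic carbon would read in this test. They also leave open whether the two cores would still read alike if a longer chain or an amine were carried on them.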